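This account rests on a few compounds, and the source may have more. Where it says the series, first, only, none or still open, it means among the compounds named here.

Compound 1 `NC(C(=O)NCC(=O)Nc1ccc(Cl)cc1C(=O)c1ccccc1)c1ccccc1` in a functional assay on the whole organism with Mus musculus as the target, in the rotarod test (a lower number here means that less compound is needed, a higher number that more compound is needed for the effect), gives > 100 mg/kg, which is a limit of the assay and not a number. Compound 2 `CN(C(=O)CNC(=O)CN)c1ccc(Cl)cc1C(=O)c1ccccc1Cl` in this assay gives 27.7 mg/kg. Compound 3 `CC(=O)NCC(=O)Nc1ccc(Cl)cc1C(=O)c1ccccc1` in this assay gives > 100 mg/kg, again a limit of the assay.

Compound 3 thus stands at the limit, where compound 1 also sits (the limit of > 100 mg/kg in this assay, at which 2 of the 3 values shown sit). Among the compounds with values here, the one measured step, a step that the two limits leave unreadable from compound 1 to compound 3, stays unreadable, both of its ends being limits. Compound 4 `CC(=O)NCC(=O)Nc1ccc(Cl)cc1C(=O)c1ccccc1Cl` arises from compound 3 by chloro in place of hydrogen on an aromatic carbon. Within the data shown here, no measured step isolates this change; compound 2 carries the same chloro and has a recorded number, while compound 3 shows only a limit, but the two differ in more than one place. The step of an at least 2.0-fold lower number from compound 3 to compound 4 (0.30 log units; that floor lies within the scatter) is therefore only an expectation, a gain of uncertain size. Compound 4 is estimated at 50 mg/kg, between 20 mg/kg and 150 mg/kg.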

Compound 4, dose for half-maximal effect: > 100 mg/kg
Compound 4 ended at the assay's limit; the forecaster's own chance of this, stated with the estimate: 40%; middle value at least 2.0-fold (0.30 log units) away from the limit.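

Compound 3 and compound 4 both sit at a limit of the assay, so the step between them cannot be read: the limit of > 100 mg/kg in this assay, at which 3 of the 4 values shown sit.

As far as these compounds go, what chloro in place of hydrogen on an aromatic carbon does in this assay therefore remains open.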